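This account rests on a few compounds, and the source may have more. Where it says the series, first, only, none or still open, it means among the compounds named here.

In a functional assay on SW1573 cells (Homo sapiens) for antiproliferative activity, read by sulforhodamine B assay, with a stated time of 48 h (on this read-out lower numbers stand for stronger inhibition of growth and higher numbers for weaker inhibition of growth), compound 2 `COC(=O)C#CC(CC(C)C)O/C=C/C(=O)OC` gives 380 nM and has the lower of the two numbers measured, while compound 3 `Cc1ccc(S(=O)(=O)C#CC(O/C=C/S(=O)(=O)c2ccc(C)cc2)C(C)C)cc1` gives 3200 nM, a higher number that lies beyond the scatter. Compound 1 `C#CCO/C=C/C(=O)OC` is different: in this assay it gives only a limit, > 100000 nM, and the limit of > 100000 nM in this assay, at which 1 of the 3 values shown sits, marks that limit rather than a number. Compound 4 `CCCCC(C#CC(=O)OC)O/C=C/C(=O)OC` is not yet measured. It differs from compound 2 by one change: propyl in place of isopropyl on a saturated chain carbon, two bonds along the chain from an oxygen on an unsaturated carbon and a triple-bonded carbon. The two share every atom, and the branch is merely straightened, so the step from compound 2 to compound 4 is expected to be small, a 1.2-fold higher number from compound 2 to compound 4 (0.07 log units; within the scatter), within the scatter or not far beyond it. For compound 4 the estimate in this assay is therefore 450 nM, somewhere between 150 nM and 1400 nM.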

Compound 4, concentration for 50% growth inhibition: 240 nM
Estimate against measurement, compound 4: 1.9-fold (0.27 log units) above; the measured number falls inside the stated range.
By their numbers in this assay, from the lowest: compounds 4 and 2 (each within the scatter of the next); then compound 3. At a limit, above all of these: compound 1.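

In this assay, putting propyl in place of isopropyl on this saturated chain carbon gives a 1.6-fold lower number from compound 2 to compound 4 (0.20 log units; within the scatter) and so shows that, for this pair, a straight or a branched group of the same three carbons cannot be told apart at this position. Nothing shown here gives a reason for this result. Going by these compounds, whether a much longer chain, a phenyl ring or an amine at this position would leave the number as little changed remains open.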